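A few compounds are considered here, and "the series" means these few. Any claim that something is new, unique, unknown or untested is made for them only; others in the source may bear on it.

Measured so far in a functional assay on SiHa cells (Homo sapiens) for inhibition, read by CCK-8 assay, with a stated time of 72 h, tested at 10 uM; on this read-out higher numbers stand for more inhibition of growth at the one concentration tested and lower numbers for less inhibition of growth:

- compound 1, `CN(C)C(=O)c1cc2cnc(Nc3ccc(NC(=O)C4(C(=O)Nc5ccccc5)CC4)cc3)nc2n1C1CCCC1`: 106%
- compound 2, `CN(C)C(=O)c1cc2cnc(Nc3ccc(NC(=O)C4(C(=O)Nc5cccc(O)c5)CC4)cc3)nc2n1C1CCCC1`: 75.7%
- compound 3, `CN(C)C(=O)c1cc2cnc(Nc3ccc(NC(=O)C4(C(=O)Nc5ccc(F)cc5)CC4)cc3F)nc2n1C1CCCC1`: 44.4%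

Compound 2 stands second of the three numbers. Its nearest neighbour is compound 1, and the step of a number 30.3 percentage points lower from compound 1 to compound 2 (beyond the scatter) lies beyond the scatter; compound 3 lies further off on the other side. Going by the values given here, compound 3 differs from compound 2 in more than one place, so only the two values themselves are compared, with no step drawn between them.

Compound 4, `CN(C)C(=O)c1cc2cnc(Nc3ccc(NC(=O)C4(C(=O)Nc5ccc(Cl)c(C(F)(F)F)c5)CC4)cc3)nc2n1C1CCCC1`, is not yet measured. Against compound 2 the change is 4-chloro-3-(trifluoromethyl)phenyl in place of 3-hydroxyphenyl on an amide-type nitrogen. Among the compounds with values here, the one measured step that bears on it is a number 30.3 percentage points lower from compound 1 to compound 2 (beyond the scatter), which removed a hydroxy group on the aromatic carbon and gave a large fall; compound 4 takes the hydroxy away again, but brings in chloro and trifluoromethyl groups for which no measured step exists. The reversal of the hydroxy step would suggest a rise; the new groups are uncharted. On balance a modest rise is expected, with wide uncertainty.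

For compound 4 the expected value in this assay is 85%, within 50% to 110%, which means an expected step of a number 9.3 percentage points higher from compound 2 to compound 4 (within the scatter).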

Compound 4, percent growth inhibition at one concentration: 61.1%
The estimate for compound 4 lay 23.9 percentage points above the measured number, within the range that was stated.
By their numbers in this assay, from the lowest: compound 3; then compound 4; then compound 2; then compound 1.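

In this assay, taking the hydroxy group away from the aryl group on the amide-type nitrogen does not by itself restore the number, as 4-chloro-3-(trifluoromethyl)phenyl gives a number 14.6 percentage points lower from compound 2 to compound 4 (beyond the scatter) and, measured against plain phenyl, a number 44.9 percentage points lower from compound 1 to compound 4 (beyond the scatter). Among compounds 1, 2 and 4, both substituted aryl groups therefore stand lower than phenyl, although 3-hydroxyphenyl counts a hydrogen-bond donor and acceptor and 4-chloro-3-(trifluoromethyl)phenyl counts none. No measurement on hand gives a reason for these falls.

Chloro and trifluoromethyl enter together, so the share of each remains open. Also open, as far as these compounds go, is whether an amine or a carboxylic acid on the phenyl ring would hold the level of compound 1 at 106%.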